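The source may report more compounds than this note shows. Statements on the series, on what has been measured and on what is new or still open speak of the compounds shown alone.

Measured so far in a functional assay on SMMC-7721 cells (Homo sapiens) for antiproliferative activity, read by MTT assay, with a stated time of 48 h (a lower number here means a stronger inhibitor, a higher number a weaker inhibitor), are three compounds:

compound 1 `CC(=O)OC/C1=C/C[C@](C)(CCC=C(C)C)/C=C/[C@@H](OC(=O)C=C(C)C)[C@](C)(OC(C)=O)/C=C/C1=O` - 4130 nM
compound 2 `COC/C1=C/C[C@](C)(CCC=C(C)C)/C=C/[C@@H](OC(=O)C=C(C)C)[C@](C)(OC)/C=C/C1=O` - 9380 nM
compound 3 `CC(C)=CCC[C@]1(C)/C=C/[C@@H](OC(=O)C=C(C)C)[C@](C)(O)/C=C/C(=O)/C(CCl)=C\C1` - 840 nM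

Compound 3 has the lowest number of the three, and compound 1 and compound 2 both lie higher, beyond the scatter. Compound 4 `CC(C)=CCC[C@]1(C)/C=C/[C@@H](OC(=O)C=C(C)C)[C@](C)(O)/C=C/C(=O)/C(CN2CCCC2)=C\C1` has not yet been measured. It differs from compound 3 by pyrrolidin-1-yl in place of chloro on a saturated chain carbon bound to a double-bonded ring carbon. Within the data shown here, no measured pair shows this change, so the guide is thin. With compound 3 at 840 nM as the lowest of the three, a moderate step to a higher number in this assay is expected, though a step within the scatter remains possible. The expected change is a 2.1-fold higher number from compound 3 to compound 4 (0.33 log units; beyond the scatter) as estimated here. For compound 4 the estimated value is 1800 nM, with an expected range from 450 nM to 7000 nM in this measurement.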

Compound 4, half-maximal inhibitory concentration: 140 nM
Estimate against measurement, compound 4: 13-fold (1.11 log units) above; measured number outside the range, below it.
By their numbers in this assay, from the lowest: compound 4; then compound 3; then compound 1; then compound 2.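

In this assay, the change from chloromethyl to (pyrrolidin-1-yl)methyl gives a 6.0-fold lower number from compound 3 to compound 4 (0.78 log units; beyond the scatter) and so shows that this place tolerates a saturated ring amine in place of chloro and that chloro is not needed for the activity seen here. Nothing available explains why the number falls. Going by these compounds, it remains open whether a piperidin-1-yl, a morpholin-4-yl or an open-chain dimethylamino group at the same place would give a lower or higher number than pyrrolidin-1-yl. On these data alone, it is also open whether a primary amine would keep the step.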